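Adding a butyl branch to a pyrimidine thioether

The source may hold more compounds than are shown below. What is called first, only, known or untested is meant among the compounds shown, and "the series" means these compounds.

Measured so far:
compound 1, `CCOC(=O)CSc1nc(Cl)cc(Nc2ccc3ncccc3c2)n1`: 2600 nM
compound 2, `CCOC(=O)C(Sc1nc(Cl)cc(Nc2cccc(C)c2C)n1)c1ccccc1`: 1800 nM

Two compounds share a chloropyrimidine core carrying an arylamine and a thioether that ends in an ethyl ester. In an assay for inhibition of Polyunsaturated fatty acid 5-lipoxygenase (Homo sapiens) (on this read-out lower numbers stand for stronger inhibition and higher numbers for weaker inhibition), compound 1 gives 2600 nM, the higher of the two numbers. Compound 2, which differs at two places at once, gives 1800 nM; the two values sit within the scatter of each other, so no order between them can be read.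

Compound 3, `CCCCC(Sc1nc(Cl)cc(Nc2ccc3ncccc3c2)n1)C(=O)OCC`, keeps everything in compound 1 except one change: butyl in place of hydrogen on a saturated chain carbon bound to a carbonyl carbon and a sulfur. Within the data shown here, no measured pair shows this exact step, so the expectation rests on the closeness of compound 1 and compound 2, which carry different groups at that same carbon without a clear difference in this assay. The step is expected to be small, if anything a slight lowering: a 1.6-fold lower number from compound 1 to compound 3 (0.21 log units; within the scatter) is the estimated change. Compound 3 is expected to give 1600 nM, with a range from 500 nM to 5000 nM.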

Compound 3, half-maximal inhibitory concentration: 1100 nM
The estimate for compound 3 lay 1.5-fold (0.16 log units) above the measured number; measured number inside the range.
By their numbers in this assay, from the lowest: compounds 3, 2 and 1 (each within the scatter of the next, the first and the last beyond it).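

Compound 1 and compound 2 differ at two places at once, so neither could isolate the effect of the saturated chain carbon bound to a carbonyl carbon and a sulfur. With the rest of compound 1 held fixed, butyl in place of hydrogen at that carbon gives, in this assay, a 2.4-fold lower number from compound 1 to compound 3 (0.37 log units; beyond the scatter), a modest step but one that lies beyond the scatter, so on this core the position accepts butyl with a gain in inhibition rather than a loss. No measurement at hand gives a reason for this gain.

From the compounds shown here alone, this rests on a single pair, so it remains open whether a shorter methyl or a longer hexyl chain at the same carbon would move the number further. Also open, going by these compounds, is how a carboxylic acid in place of the ethyl ester would read out alongside the butyl branch.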